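A new group on the ring nitrogen of compound 2

The source may hold more compounds than are shown below. What is called first, only, known or untested is meant among the compounds shown, and "the series" means these compounds.

Going by the values given here, in a functional assay on HL-60 cells (Homo sapiens) for inhibition, read by MTT assay, with a stated time of 72 h (a higher number here means a weaker inhibitor, a lower number a stronger inhibitor), compound 2 `Cc1ccc(C)c(N2CCN(C(=O)c3oc(C)nc3-c3ccc(F)cc3)CC2)c1` gives 358 nM, the higher of the two numbers measured so far. Compound 3 `Cc1ccc(C)c(N2CCN(C(=O)c3oc(C)nc3-c3ccccc3)CC2)c1` gives 31.3 nM. Replacing fluoro with hydrogen on an aromatic carbon produces an 11-fold lower number from compound 2 to compound 3 (1.06 log units; beyond the scatter), a large step beyond the scatter.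

Compound 4 `Cc1nc(-c2ccc(F)cc2)c(C(=O)N2CCN(c3ccc(Cl)cc3)CC2)o1` keeps the fluoro and differs from compound 2 elsewhere, as 4-chlorophenyl in place of 2,5-dimethylphenyl on an amine nitrogen in a ring shows: 4-chlorophenyl in place of 2,5-dimethylphenyl on an amine nitrogen in a ring. Among the compounds with values here, no measured step isolates this swap, and the large step above lies at another place in the molecule, so it warns only that one small edit moved the number a lot here.

The closest evidence is compound 1 `Cc1nc(-c2ccc(F)cc2)c(C(=O)N2CCN(c3ccc(C(=O)C(C)C)cc3)CC2)o1`, which keeps the fluoro and carries another group on that nitrogen. In this assay, compound 1 gives "not active" (no number reported), with no number reported. A weaker result is therefore expected, though with wide uncertainty. The expected change is a 2.5-fold higher number from compound 2 to compound 4 (0.40 log units; beyond the scatter). For compound 4 the estimated value is 900 nM, with an expected range from 200 nM to 4000 nM.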

Compound 4, half-maximal inhibitory concentration: "not active" (no number reported)
The entry for compound 4 holds no number; no gap can be computed for the estimate.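

Going by these compounds alone, compound 4, like compound 1, has no number, so no step from compound 2 to compound 4 can be read. Nothing measured here accounts for this result. The compounds shown leave open how far 4-chlorophenyl in place of 2,5-dimethylphenyl moves the number.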